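A few compounds are considered here, and "the series" means these few. Any claim that something is new, unique, unknown or untested is made for them only; others in the source may bear on it.

Measured in a functional assay on HeLa cells (Homo sapiens) for antiproliferative activity, read by MTT assay, with a stated time of 72 h; on this read-out lower numbers stand for stronger inhibition and higher numbers for weaker inhibition:
Compound 1 `C=C(Br)C(=O)Nc1ccc2c(c1)/C(=C\c1sccc1C)C(=O)N2`: 450 nM
Compound 2 `C=C(Br)C(=O)Nc1ccc2c(c1)/C(=C/c1ccc[nH]1)C(=O)N2`: 500 nM
Compound 3 `C#CC(=O)Nc1ccc2c(c1)/C(=C/c1ccc[nH]1)C(=O)N2`: 4400 nM

Compound 2, at 500 nM, and compound 1, at 450 nM, lie within the scatter of each other. Compound 3 stands apart, with a modest step beyond the scatter: an 8.8-fold higher number from compound 2 to compound 3 (0.94 log units; beyond the scatter).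

Compound 4 `C=C(Br)C(=O)Nc1ccc2c(c1)/C(=C/c1sccc1C)C(=O)N2` has not yet been measured. It differs from compound 2 as follows: 3-methylthiophen-2-yl in place of 1H-pyrrol-2-yl on a double-bonded chain carbon bound to a double-bonded ring carbon. In words, it has 3-methylthiophen-2-yl in place of 1H-pyrrol-2-yl on a double-bonded chain carbon bound to a double-bonded ring carbon.

Among the compounds with values here, no measured step isolates this change. Within the data shown here, the one step available concerns ethynyl in place of 1-bromoethenyl on a carbonyl carbon, so it shows only that this small set can move, not how far this swap will move it. The nearest evidence is compound 1, which carries the same 3-methylthiophen-2-yl and 1-bromoethenyl groups but has the opposite geometry at the double bond. Its value of 450 nM points to no large shift, so no step beyond the scatter is expected in this assay. The expected step is a 1.1-fold lower number from compound 2 to compound 4 (0.05 log units; within the scatter).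

Compound 4 is estimated at 450 nM, with an expected range of 170 nM to 1200 nM.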

Compound 4, half-maximal inhibitory concentration: 420 nM
Compound 4: middle estimate off by 1.1-fold (0.03 log units), on the high side; the range from low to high includes it.
By their numbers in this assay, from the lowest: compounds 4, 1 and 2 (each within the scatter of the next); then compound 3.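

In this assay, the place on the double-bonded chain carbon bound to a double-bonded ring carbon accepts 3-methylthiophen-2-yl in place of 1H-pyrrol-2-yl with no step beyond the scatter, a 1.2-fold lower number from compound 2 to compound 4 (0.08 log units; within the scatter), even though the entering group has no hydrogen-bond donor and the leaving group has one. The drawn geometry at the double bond also leaves the number within the scatter, a 1.1-fold lower number from compound 1 to compound 4 (0.03 log units; within the scatter), and this pair reads that one feature alone: the fact that compounds 1 and 4 differ only in the configuration as drawn. Among these compounds, the only step beyond the scatter therefore remains the change on the carbonyl carbon, an 8.8-fold higher number from compound 2 to compound 3 (0.94 log units; beyond the scatter), while neither change at the double-bonded chain carbon yields one.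

The compounds shown leave open whether this tolerance extends to groups of another kind at the same place, such as a phenyl ring, a carboxylic acid or a dimethylamine on a longer chain. They also leave open whether geometry matters as little with 1H-pyrrol-2-yl as with 3-methylthiophen-2-yl, and whether ethynyl on the carbonyl carbon would give a similar step with 3-methylthiophen-2-yl in place.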